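Compound 4: oxolanyloxy group in place of 2-acetylethyl

This account rests on a few compounds, and the source may have more. Where it says the series, first, only, none or still open, it means among the compounds named here.

Three compounds of the series have numbers in an assay on isolated protein for inhibition of ATP-dependent RNA helicase DDX3X (Homo sapiens), read by FRET, with stated times of 30 s and 40 min; on this read-out lower numbers stand for stronger inhibition and higher numbers for weaker inhibition. Compound 1 `CCCCc1cn(-c2ccc(NC(=O)Nc3cc(CCC(C)=O)ccc3C)cc2)nn1` gives 2490 nM, the highest of the three. Compound 2 `COCCc1cn(-c2ccc(NC(=O)Nc3ccccc3C)cc2)nn1` gives 1000 nM, and compound 3 `CCOP(=O)(OCC)OCCc1cn(-c2ccc(NC(=O)Nc3ccccc3C)cc2)nn1` gives 890 nM. Among the measured compounds shown here, the only single-place step among them is a 1.1-fold lower number from compound 2 to compound 3 (0.05 log units; within the scatter), so a much larger polar group on that chain left the number where it was. Compound 1 and compound 2 differ in more than one place, so their values are simply set side by side: compound 1 stands higher than compound 2 by more than the scatter.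

Compound 4 `CCCCc1cn(-c2ccc(NC(=O)Nc3cc(O[C@H]4O[C@@H](CO)[C@H](O)[C@@H]4O)ccc3C)cc2)nn1` is the next compound to be measured. It differs from compound 1 by (3,4-dihydroxy-5-(hydroxymethyl)oxolan-2-yl)oxy in place of 2-acetylethyl on an aromatic carbon. For the measured compounds named here, no measured step touches this aromatic carbon, so nothing bears on it directly; the only guide is that the one measured step, from compound 2 to compound 3, stayed within the scatter when a large oxygen-rich group entered. On that basis compound 4 is expected to move by a 1.1-fold lower number from compound 1 to compound 4 (0.05 log units; within the scatter), that is no step beyond the scatter in this assay. The estimate for compound 4 is 2200 nM, with a range from 800 nM to 6000 nM.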

Compound 4, half-maximal inhibitory concentration: "not active" (no number reported)
Compound 4: no number reported, so the estimate cannot be set against anything.
By their numbers in this assay, from the lowest: compounds 3 and 2 (each within the scatter of the next); then compound 1.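

In this assay, among the compounds shown here, compound 4 is reported as "not active" with no number, so no step from compound 1 to compound 4 can be read. The compounds shown leave open how the (3,4-dihydroxy-5-(hydroxymethyl)oxolan-2-yl)oxy group acts on this aromatic carbon in numerical terms. No data shown bear on the reason for this result.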